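Cyclopentyl for 4-fluorophenyl on the Ring Nitrogen

The source may report more compounds than this note shows. Statements on the series, on what has been measured and on what is new or still open speak of the compounds shown alone.

Measured compounds:
compound 1 `CCC(CC)n1c(-c2ccc(OCc3c(-c4c(Cl)cccc4Cl)noc3C(C)C)cc2F)nc2ccc(C(=O)O)cc21` — > 10000 nM
compound 2 `CC(C)c1onc(-c2c(Cl)cccc2Cl)c1COc1ccc(-c2nc3ccc(C(=O)O)cc3n2CC2CCCCC2)c(F)c1` — 840 nM
compound 3 `CC(C)c1onc(-c2c(Cl)cccc2Cl)c1COc1ccc(-c2nc3ccc(C(=O)O)cc3n2-c2ccc(F)cc2)cc1` — 2410 nM

In an assay on HEK-293T cells for antagonist activity at vitamin D3 receptor (Homo sapiens), read by a luciferase reporter, with a stated time of 24 h (on this read-out higher numbers stand for weaker inhibition and lower numbers for stronger inhibition), compound 1 gives only a limit, > 10000 nM, not a number. Compound 3 stands highest of the two numbers in this assay with 2410 nM, and compound 2 gives 840 nM. Compound 4 `CC(C)c1onc(-c2c(Cl)cccc2Cl)c1COc1ccc(-c2nc3ccc(C(=O)O)cc3n2C2CCCC2)cc1` differs from compound 3 in one place: cyclopentyl in place of 4-fluorophenyl on an aromatic nitrogen. Going by the values given here, the one measured step at the same aromatic nitrogen, an at least 11-fold lower number from compound 1 to compound 2 (1.07 log units; beyond the scatter), swapped one alkyl for another and resting on the limit of > 10000 nM in this assay, at which 1 of the 3 values shown sits, its true size is unknown; it gives only a loose hint that a saturated ring there can be tolerated. Compound 4 is therefore expected to show a 2.4-fold lower number from compound 3 to compound 4 (0.38 log units; beyond the scatter), a modest drop. The estimate for compound 4 is 1000 nM, within 300 nM to 3500 nM.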

Compound 4, half-maximal inhibitory concentration: 929 nM
The estimate for compound 4 lay 1.1-fold (0.03 log units) above the measured number; the measured number falls inside the stated range.
By their numbers in this assay, from the lowest: compounds 2 and 4 (each within the scatter of the next); then compound 3. At a limit, above all of these: compound 1.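

In this assay, going by these compounds alone, cyclopentyl in place of 4-fluorophenyl gives a 2.6-fold lower number from compound 3 to compound 4 (0.41 log units; beyond the scatter), the first step at this aromatic nitrogen whose size can be read. It shows that an aromatic ring is not required at this position, and that a five-membered non-aromatic carbon ring gives the lower number of the pair. The earlier step at this nitrogen could not show this, as its size stays unknown: the limit of > 10000 nM in this assay, at which 1 of the 4 values shown sits.

As far as these compounds go, it remains open how a plain phenyl, without the fluorine, would compare with 4-fluorophenyl here. Also open, from the compounds shown here alone, is whether an amine-bearing ring or a longer chain such as n-butyl on this nitrogen would lower the number further.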